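The compounds below may be only part of what the source reports. "The series", "measured", "known", "first", "only" and "open" are said of these compounds alone.

Measured compounds:
Compound 1, `CC(O)(C(=O)Nc1cccc(S(=O)(=O)c2ccccc2)c1)C(F)(F)F`: in a functional assay (Cavia porcellus) with sulfonylurea receptors; K-ATP channels (Homo sapiens) as the target (on this read-out higher numbers stand for weaker inhibition and lower numbers for stronger inhibition), compound 1 gives > 30000 nM, which is a limit of the assay and not a number.
Compound 2, `CC(O)(C(=O)Nc1ccc(S(=O)(=O)c2ccc(F)cc2)cc1)C(F)(F)F`: in this assay compound 2 gives 8600 nM.
Compound 3, `COc1cc(NC(=O)C(C)(O)C(F)(F)F)ccc1S(=O)(=O)c1ccccc1`: in this assay compound 3 gives 5900 nM.

Among the two numbers shown, compound 2 stands at the higher one, and compound 3 sits within the scatter of it, so the two cannot be placed in order. Compound 1 gave only a limit, (the limit of > 30000 nM in this assay, at which 1 of the 3 values shown sits).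

Compound 4, `COc1ccccc1S(=O)(=O)c1ccc(NC(=O)C(C)(O)C(F)(F)F)cc1`, has not been measured in this assay. It differs from compound 2 in one place: 2-methoxyphenyl in place of 4-fluorophenyl on a sulfonyl sulfur. Among the compounds with values here, no measured pair shows such a change on the sulfonyl side, and compound 3, which carries a methoxy group on the other aromatic ring, stays within the scatter of compound 2. The step from compound 2 to compound 4 is therefore expected to be small, a 1.2-fold lower number from compound 2 to compound 4 (0.09 log units; within the scatter), with no clear direction beyond the scatter. For compound 4 the estimate in this assay is 7000 nM, expected to fall between 2500 nM and 25000 nM.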

Compound 4, half-maximal inhibitory concentration: 1600 nM
Compound 4: middle estimate off by 4.4-fold (0.64 log units), on the high side, outside the stated range (below it).
By their numbers in this assay, from the lowest: compound 4; then compounds 3 and 2 (each within the scatter of the next). At a limit, above all of these: compound 1.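

In this assay, within the data shown here, the group on the sulfonyl sulfur proves able to move the read-out: 2-methoxyphenyl in place of 4-fluorophenyl gives a 5.4-fold lower number from compound 2 to compound 4 (0.73 log units; beyond the scatter) as the first step between measured compounds that differ in one place. The step is modest but lies beyond the scatter, so this position is not silent in this read-out. The entering group has one more heavy atom and one hydrogen-bond acceptor where the leaving group has none, but no measurement shown here bears on the cause of the step.

The compounds shown leave open whether the step follows the arrival of the methoxy group or the departure of the fluorine. They also do not tell how an ethoxy group or an amine in place of that methoxy group would read in this assay.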